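Swapping Fluoro for Methyl on the Urea Aryl Ring

The compounds below may be only part of what the source reports. "The series", "measured", "known", "first", "only" and "open" are said of these compounds alone.

Compound 1, `CN(C)CCCNc1nc(-c2ccc(NC(=O)Nc3ccc(Cl)cc3Cl)cc2)nc2c(Cl)c(Cl)sc12`, gives 980 nM in a functional assay on NCI-H460 cells (Homo sapiens) for cytotoxicity, read by MTT assay, with a stated time of 72 h; a higher number here means a weaker inhibitor, a lower number a stronger inhibitor. Compound 2, `CN(C)CCNc1nc(-c2ccc(NC(=O)Nc3ccc(F)cc3)cc2)nc2ccsc12`, gives 390 nM in this assay. Compound 3, `CN(C)CCNc1nc(-c2ccc(NC(=O)Nc3ccc(Cl)cc3Cl)cc2)nc2c(Cl)c(Cl)sc12`, gives 1520 nM in this assay.

Among these three numbers, compound 2 stands lowest, which in this assay means the strongest inhibitor of the set; its nearest neighbour is compound 1, and compound 3 lies furthest away, both beyond the scatter. Compound 4, `Cc1ccc(NC(=O)Nc2ccc(-c3nc(NCCN(C)C)c4sccc4n3)cc2)cc1`, differs from compound 2 by one change: methyl in place of fluoro on an aromatic carbon. Within the data shown here, the only measured step among the three compounds is a 1.6-fold higher number from compound 1 to compound 3 (0.19 log units; within the scatter), and it concerns the amine-bearing chain, not the aryl ring of the urea, so no measured step bears on the change from compound 2 to compound 4. With nothing to point either way, the expectation for compound 4 is a number close to that of compound 2, with the step of a 1.1-fold higher number from compound 2 to compound 4 (0.03 log units; within the scatter) estimated to stay within the scatter. The estimate for compound 4 is 420 nM, with a range from 150 nM to 1200 nM.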

Compound 4, half-maximal inhibitory concentration: 1880 nM
For compound 4 the middle estimate is 4.5-fold (0.65 log units) below the measured one; measured number above the stated range.
By their numbers in this assay, from the lowest: compound 2; then compounds 1, 3 and 4 (each within the scatter of the next).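

Going from 4-fluorophenyl to 4-methylphenyl, with the rest of the molecule unchanged, is the first measured change at this position, and in this assay it brings a 4.8-fold higher number from compound 2 to compound 4 (0.68 log units; beyond the scatter) and so a weaker inhibitor. Fluoro and methyl each count one heavy atom and neither carries a hydrogen-bond donor or acceptor, so a swap that leaves these counts unchanged can still move the number beyond the scatter. Nothing measured here explains the size or direction of this step.

On these data alone, this single pair is all that speaks for the position, so it remains open how methoxy, a nitrile or a plain phenyl ring would compare with fluoro and methyl in the same place. Also open, as far as these compounds go, is whether the same swap would give a step of similar size on the core of compound 3.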